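The source may report more compounds than this note shows. Statements on the series, on what has been measured and on what is new or still open speak of the compounds shown alone.

Measured so far:
- compound 1 `Nc1ccccc1NC(=O)c1ccc(CSC(=S)N2CCN(C3CCCCC3)CC2)cc1`: 30.6%
- compound 2 `Nc1ccccc1NC(=O)c1ccc(CSC(=S)N2CCc3cc([N+](=O)[O-])ccc32)cc1`: 32.6%

In a functional assay on HeLa cells (Homo sapiens) for antiproliferative activity, read by CCK-8 assay, with a stated time of 72 h, tested at 2 uM (a higher number here means a stronger effect of the compound at the concentration tested, a lower number a weaker effect), compound 1 gives 30.6% and compound 2 gives 32.6%. The gap between these two numbers lies within the usual scatter of the read-out, so compound 1 cannot be set apart from compound 2 on the data so far; both stand in the same band of moderate inhibition.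

Compound 3 `Nc1ccccc1NC(=O)c1ccc(CSC(=S)N2CCN(c3ccc(F)cc3)CC2)cc1` has not yet been measured in this assay. Against compound 1 it differs in one place:
4-fluorophenyl in place of cyclohexyl on an amine nitrogen in a ring
The shared core of compound 1 is otherwise kept intact.

Among the measured compounds shown here, no step between measured compounds is available, and the only pair on record, compound 1 against compound 2, shows values within the scatter of each other. On that basis a step of no more than modest size is expected, in either direction, and most likely none beyond the scatter. The step of a number 2.4 percentage points higher from compound 1 to compound 3 (within the scatter) is therefore estimated to be small. Compound 3 is expected to give 33%, with a range from 18% to 50%.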

Compound 3, a percentage reported as inhibition, at one concentration (the size of the read-out at that concentration, not a potency): 60.8%
For compound 3 the middle estimate is 27.8 percentage points below the measured one; the whole stated range lies below it.
By their numbers in this assay, from the lowest: compounds 1 and 2 (each within the scatter of the next); then compound 3.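

In this assay, the group on the amine nitrogen in the six-membered non-aromatic ring with 2 nitrogen proves to be a sensitive point of the series: 4-fluorophenyl in place of cyclohexyl gives a number 30.2 percentage points higher from compound 1 to compound 3 (beyond the scatter). Both groups are six-membered rings of carbon with no hydrogen-bond donors or acceptors and no net charge, yet the change from a non-aromatic ring to an aromatic ring bearing fluorine comes with a large step, which the earlier pair, differing in more than one place, could not reveal. No measurement at hand bears on what lies behind this step.

The compounds shown leave open whether the aromatic ring alone or the fluorine goes with the step, a question that plain phenyl on the same nitrogen would separate. Also open, from the compounds shown here alone, is whether a chlorine or a methoxy group in place of the fluorine, or a pyridine ring in place of the benzene ring, would keep the level of compound 3 at 60.8% in this assay.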